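A Carbonate Variant of a Labile Ester Prodrug

The source may hold more compounds than are shown below. What is called first, only, known or untested is meant among the compounds shown, and "the series" means these compounds.

Compound 1, `CC(C)C(=O)OCOC(=O)C1=C(S[C@@H]2CN[C@H](C(=O)Nc3cccc(C(=O)O)c3)C2)[C@H](C)[C@@H]2[C@@H]([C@@H](C)O)C(=O)N12`, stands at the bottom of the three numbers measured in an ADME assay on a cell-free system (plasma, Rattus norvegicus) for metabolic stability, read by LC-MS, with a stated time of 60 min, at 37 degrees C, tested at 50 uM (on this read-out lower numbers stand for a less stable compound and higher numbers for a more stable compound), giving 0%. Compound 2, `CC(C)C(=O)OCOC(=O)C1=C(S[C@@H]2CN[C@H](C(=O)Nc3cccc(C(=O)OCOC(=O)C(C)C)c3)C2)[C@H](C)[C@@H]2[C@@H]([C@@H](C)O)C(=O)N12`, gives 1%, and the step of a number 1 percentage points higher from compound 1 to compound 2 (within the scatter) lies within the scatter of repeated measurements. Compound 3, `CCCCCCCCCCCCCCCCOC(=O)C1=C(S[C@@H]2CN[C@H](C(=O)Nc3cccc(C(=O)OCCCCCCCCCCCCCCCC)c3)C2)[C@H](C)[C@@H]2[C@@H]([C@@H](C)O)C(=O)N12`, gives 89%, which stands far beyond the scatter away from compound 1 and compound 2.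

The unmeasured compound 4, `CCOC(=O)OCOC(=O)C1=C(S[C@@H]2CN[C@H](C(=O)Nc3cccc(C(=O)O)c3)C2)[C@H](C)[C@@H]2[C@@H]([C@@H](C)O)C(=O)N12`, differs from compound 1 in one place: ethoxy in place of isopropyl on a carbonyl carbon. Read one bond further out, the change is from ((isopropylcarbonyl)oxy)methyl to ((ethoxycarbonyl)oxy)methyl, while the free acid of compound 1 is kept. Within the data shown here, no measured step touches this carbonyl carbon. Among the measured compounds shown here, the only measured step nearby, a number 1 percentage points higher from compound 1 to compound 2 (within the scatter), added a second ((isopropylcarbonyl)oxy)methyl group and moved nothing beyond the scatter. Compound 4 is therefore expected to stay close to compound 1, with a step of a number 5 percentage points higher from compound 1 to compound 4 (within the scatter) in this assay, not beyond the scatter. The estimate for compound 4 is 5%, within a range from 0% to 25%.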

Compound 4, percent of the compound remaining: 0%
Compound 4: middle estimate off by 5 percentage points, on the high side; low and high end bracket the measured number.
By their numbers in this assay, from the lowest: compounds 1, 4 and 2 (each within the scatter of the next); then compound 3.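

Ethoxy in place of isopropyl on this carbonyl carbon, the first change measured at this place, gives no change at the digits printed from compound 1 to compound 4 (within the scatter) in this assay. With the free acid kept, the ((ethoxycarbonyl)oxy)methyl group gives a reading no different from that of the ((isopropylcarbonyl)oxy)methyl group, and at a reading this low the assay has no room left to separate the two groups any further. No measurement shown explains what happens to either group during the incubation.

Still open, on these data alone, is whether a bulkier tert-butyl group or a longer chain, such as hexyloxy, on this carbonyl carbon would lift the number off the bottom of the read-out. Compound 3 differs from compound 1 in more than one place, so it does not settle that question.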